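A few compounds are considered here, and "the series" means these few. Any claim that something is new, unique, unknown or untested is made for them only; others in the source may bear on it.

Among the compounds with values here, compound 1 `COc1ccc(C(=O)/C=C/c2cc(-c3cc(OC)c(OC)c(OC)c3)n[nH]2)cc1OC` is the only compound among those measured that gives a number in a functional assay on Hs-578T cells (Homo sapiens) for inhibition, read by sulforhodamine B assay, with a stated time of 48 h; a higher number here means a weaker inhibitor of growth, a lower number a stronger inhibitor of growth: compound 1 gives 8200 nM. Compound 2 `COc1ccc(C(=O)/C=C/c2cc(-c3cc(OC)c(OC)c(OC)c3)n[nH]2)cc1` differs by a hydrogen in place of a methoxy on an aromatic carbon. In this assay compound 2 reaches only the limit > 100000 nM, which is a limit and not a number. The step of an at least 12-fold higher number from compound 1 to compound 2 (1.08 log units; beyond the scatter) is therefore large, a loss of growth inhibition on removing a methoxy, as far as the limit of > 100000 nM in this assay, at which 1 of the 2 values shown sits, allows one to see. Compound 3 `COc1cc(C(=O)/C=C/c2cc(-c3cc(OC)c(OC)c(OC)c3)n[nH]2)cc(OC)c1OC` goes the other way: methoxy in place of hydrogen on an aromatic carbon. Within the data shown here, the single measured step bears on it only by analogy, as it runs in the opposite direction, so a gain in inhibition, smaller than that loss, is expected. Compound 3 is estimated at 4000 nM, with a range of 1200 nM to 15000 nM. The expected step is a 2.1-fold lower number from compound 1 to compound 3 (0.31 log units; beyond the scatter).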

Compound 3, concentration for total growth inhibition: 53900 nM
Compound 3: the middle estimate sits 13-fold (1.13 log units) below what was measured; measured number above the stated range.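

In this assay, the added methoxy, on an aromatic carbon ortho to a methoxy group and meta to a large group, gives a 6.6-fold higher number from compound 1 to compound 3 (0.82 log units; beyond the scatter), so this change weakens growth inhibition instead of strengthening it. The earlier compounds showed only that taking a methoxy away costs inhibition; now a change in either direction from compound 1 raises the number, and of the three compounds shown, compound 1 has the lowest. The value of compound 2 is a limit and not a number, so the two losses cannot be sized against each other: the limit of > 100000 nM in this assay, at which 1 of the 3 values shown sits.

The compounds shown leave open whether the loss in compound 3 is specific to methoxy. A hydroxyl, a fluorine or an amine at this same carbon could still behave differently.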